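From Propanamide to Aryl Urea on a Shared Core

The source may hold more compounds than are shown below. What is called first, only, known or untested is meant among the compounds shown, and "the series" means these compounds.

Of the compounds shown here, three built on one shared core have been tested in a functional assay on HCT-116 cells (Homo sapiens) for antiproliferative activity, read by MTT assay, with a stated time of 72 h; on this read-out lower numbers stand for stronger inhibition and higher numbers for weaker inhibition. Compound 1 `CCC(=O)N(C)c1ccc2[nH]c(-c3n[nH]c4ccccc34)cc2n1` carries a propanamide on the amide-type nitrogen and in this assay gives 10800 nM. Compound 2 `COc1ccc(S(=O)(=O)N(C)c2ccc3[nH]c(-c4n[nH]c5ccccc45)cc3n2)cc1OC` carries a sulfonyl group instead and gives 16700 nM, while compound 3 `COc1ccc(S(=O)(=O)N(C)c2ccc3[nH]c(-c4n[nH]c5ccccc45)cc3n2)c(OC)c1` gives 21800 nM. Compound 1 thus shows the lowest number of the three; its gap to compound 2 lies within the scatter, and only its gap to compound 3 lies beyond it. Among the compounds with values here, the one measured step, a 1.3-fold higher number from compound 2 to compound 3 (0.12 log units; within the scatter), compares two sulfonyl aryl groups and says nothing about the carbonyl side chain.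

Compound 4 `COc1ccc(NC(=O)N(C)c2ccc3[nH]c(-c4n[nH]c5ccccc45)cc3n2)cc1` is not yet measured. Its change from compound 1 is (4-methoxyphenyl)amino in place of ethyl on a carbonyl carbon. Within the data shown here, no measured step bears on this urea-forming change, so there is no basis for expecting a step beyond the scatter in either direction. The expected step is a 1.5-fold lower number from compound 1 to compound 4 (0.19 log units; within the scatter). Compound 4 is therefore estimated at 7000 nM, within a range from 2000 nM to 25000 nM.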

Compound 4, half-maximal inhibitory concentration: 63 nM
For compound 4 the middle estimate is 110-fold (2.05 log units) above the measured one; the measured number lies below the stated range.
By their numbers in this assay, from the lowest: compound 4; then compounds 1, 2 and 3 (each within the scatter of the next, the first and the last beyond it).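

The carbonyl carbon on the amide-type nitrogen proves to be a place where one change can move the result greatly: in this assay, (4-methoxyphenyl)amino in place of ethyl gives a 170-fold lower number from compound 1 to compound 4 (2.23 log units; beyond the scatter) on this read-out. Within the data shown here, the earlier compounds could not show this, as their one measured step, a 1.3-fold higher number from compound 2 to compound 3 (0.12 log units; within the scatter), compares two sulfonyl aryl groups and stays within the scatter. The entering group brings more heavy atoms, an aromatic ring, a hydrogen-bond donor and a hydrogen-bond acceptor all at once, and nothing measured here explains the size of the step.

The compounds shown do not reveal which part of the new group matters. A phenylamino group without the methoxy, a methylamino group without the ring, or a 4-methoxyphenyl group without the amino nitrogen could begin to separate these parts.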